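A few compounds are considered here, and "the series" means these few. Any claim that something is new, unique, unknown or untested is made for them only; others in the source may bear on it.

Among the compounds with values here, in a functional assay on the whole organism (strain Hartley) for inhibition, with Cavia porcellus as the target, with stated times of 15 min and 2 min (a lower number here means that less compound is needed, a higher number that more compound is needed for the effect), compound 2 `CCCCC1([C@H](O)/C=C/C2[C@H](O)CC(=O)[C@@H]2C/C=C\CCCC(=O)O)CCC1` gives 0.00251 mg/kg, the lower of the two numbers measured so far. Compound 1 `CCCCC1([C@@H](O)/C=C/C2[C@H](O)CC(=O)[C@@H]2CCCCCCC(=O)O)CCC1` gives 0.0439 mg/kg, and that gap lies beyond the usual scatter, so compound 2 needs clearly less compound for the effect. Compound 3 `CCCCC1([C@H](O)/C=C/C2[C@H](O)CC(=O)[C@@H]2CCCCCCC(=O)O)CCC1` differs from compound 2 in one place, with 5-carboxypentyl in place of 5-carboxypent-1-en-1-yl on a saturated chain carbon bound to a saturated ring carbon. Within the data shown here, no measured pair shows this change on its own, so the expectation is uncertain. A modest move towards a higher number is expected in this assay, an estimated 2.4-fold higher number from compound 2 to compound 3 (0.38 log units; beyond the scatter). The expected value for compound 3 is 0.006 mg/kg, with a range from 0.002 mg/kg to 0.02 mg/kg.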

Compound 3, dose for half-maximal effect: 0.00126 mg/kg
Estimate against measurement, compound 3: 4.8-fold (0.68 log units) above, and the stated range ends above it.
By their numbers in this assay, from the lowest: compounds 3 and 2 (each within the scatter of the next); then compound 1.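

In this assay the change from 5-carboxypent-1-en-1-yl to 5-carboxypentyl gives a 2.0-fold lower number from compound 2 to compound 3 (0.30 log units; within the scatter) so this chain shows no clear preference between the two forms. The configuration at the saturated chain carbon carrying the hydroxyl matters much more, with a 35-fold lower number from compound 1 to compound 3 (1.54 log units; beyond the scatter) even though the two compounds share the same atoms and bonds. That large gap traces to a single difference: the fact that one of compounds 1 and 3 is drawn with a defined configuration and the other without, at the place where they differ. As far as these compounds go, it remains open whether the same configuration has as large an effect with the 5-carboxypent-1-en-1-yl chain. From the compounds shown here alone, how a tetrazole in place of the carboxylic acid would behave also remains open.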